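Swapping a methoxypyridine for a quinoline on the amide

The compounds below may be only part of what the source reports. "The series", "measured", "known", "first", "only" and "open" are said of these compounds alone.

Three compounds share one core and were tested in a functional assay on the whole organism (blood) with Rattus norvegicus as the target, with stated times of 24 h and 1 h, at a dose of 5 mg/kg by the intraperitoneal route; a lower number here means a weaker effect, a higher number a stronger effect of the compound at the dose given. Compound 1 `CCCNC(=O)NS(=O)(=O)N1CCC(CCNC(=O)c2cc(C(F)(F)F)nn2C)CC1` gives 11%, compound 2 `O=C(NC1CCCCC1)NS(=O)(=O)N1CCC(CCNC(=O)c2cscn2)CC1` gives 23%, and compound 3 `COc1ccc(C(=O)NCCC2CCN(S(=O)(=O)NC(=O)NC[C@@H]3C[C@@H]4C=C[C@@H]3C4)CC2)cn1` gives 11%. On these numbers compound 3 sits level with compound 1, the two together at the low end, while compound 2 lies higher by a margin beyond the usual scatter. Compound 4 `O=C(NC[C@@H]1C[C@@H]2C=C[C@@H]1C2)NS(=O)(=O)N1CCC(CCNC(=O)c2cccc3cccnc23)CC1` has not been measured; it differs from compound 3 in one place (quinolin-8-yl in place of 6-methoxypyridin-3-yl on a carbonyl carbon). Among the compounds with values here, no measured pair isolates this change, so the expected step in this assay from compound 3 to compound 4 is small, a number 4 percentage points higher from compound 3 to compound 4 (within the scatter), and may not exceed the scatter. Compound 4 is therefore estimated at 15%, within 3% to 32%.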

Compound 4, a percentage reported as activity, at one dose (the size of the read-out at that dose, not a potency): 34%
Beside the measured number, compound 4's estimate is 19 percentage points below it, and the stated range ends below it.
By their numbers in this assay, from the lowest: compounds 1 and 3 (each within the scatter of the next); then compound 2; then compound 4.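

In this assay, putting quinolin-8-yl in place of 6-methoxypyridin-3-yl on a carbonyl carbon gives a number 23 percentage points higher from compound 3 to compound 4 (beyond the scatter) with the rest of the molecule unchanged. Within the data shown here, this is the first pair here that differs in one place, and it shows that the group on this carbonyl alone can move the read-out beyond the usual scatter. Open, from the compounds shown here alone, is whether this rise needs the ring nitrogen or the second ring, which a naphthalen-1-yl or a plain phenyl group on the same carbonyl could separate. Nothing available gives a reason for the rise.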